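Methyl for Chloro on Two Related Fused Cores

The source may hold more compounds than are shown below. What is called first, only, known or untested is meant among the compounds shown, and "the series" means these compounds.

Compound 1 `Cc1ccc2c(c1)CCCN2c1nc(Cl)nc2ccccc12` was tested in a functional assay on KBVIN cells (Homo sapiens) for cytotoxicity, read by sulforhodamine B assay (on this read-out higher numbers stand for weaker inhibition of growth and lower numbers for stronger inhibition of growth), where compound 1 gives 46 nM. Compound 2 `Cc1ccc2c(c1)CCCN2c1nc(C)nc2ccccc12` differs from it by methyl in place of chloro on an aromatic carbon, and in this assay compound 2 gives 176 nM. That single change produced the step of a 3.8-fold higher number from compound 1 to compound 2 (0.58 log units; beyond the scatter). Compound 3 `COc1ccc2c(c1)CCN2c1nc(Cl)nc2ccccc12` rests on a different core; how the two cores differ is not broken down here. In this assay compound 3 gives 197 nM, a number close to that of compound 2 and beyond the scatter away from that of compound 1. Compound 4 `COc1ccc2c(c1)CCN2c1nc(C)nc2ccccc12`, not yet measured, differs from compound 3 by methyl in place of chloro on an aromatic carbon, the same change as made on the core of compound 1, so the change occurs twice in all among these compounds. For the measured compounds named here, because the only measured example of this change gave the step of a 3.8-fold higher number from compound 1 to compound 2 (0.58 log units; beyond the scatter), a step of similar size is expected on the second core, and the expectation for compound 4 is the step of a 3.8-fold higher number from compound 3 to compound 4 (0.58 log units; beyond the scatter). In this assay compound 4 is therefore estimated to give 750 nM, with a likely range from 350 nM to 1600 nM.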

Compound 4, concentration for 50% growth inhibition: 216 nM
The estimate for compound 4 lay 3.5-fold (0.54 log units) above the measured number; measured number below the stated range.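

In this assay, methyl in place of chloro on the second core gave a 1.1-fold higher number from compound 3 to compound 4 (0.04 log units; within the scatter), so on this core the change did not move the number beyond the scatter. Set beside the earlier case, the same change did not carry over in size from one core to the other: the same change on two cores in this assay, a 3.8-fold higher number (0.58 log units; beyond the scatter) from compound 1 to compound 2 and a 1.1-fold higher number (0.04 log units; within the scatter) from compound 3 to compound 4, 3.5-fold (0.54 log units) apart, beyond the scatter of two such steps. For the compounds shown here, this shows that, in this series, a step measured on one core cannot simply be transferred to the other, but with only two pairs it does not show which feature of the cores matters, nor how the change would behave on any further core.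

The compounds shown leave open how other groups on this aromatic carbon between two ring nitrogen atoms would compare, such as an amine, a nitrile or a longer chain. They also leave open whether the gap between the two steps would hold in another cell line.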